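A few compounds are considered here, and "the series" means these few. Any claim that something is new, unique, unknown or untested is made for them only; others in the source may bear on it.

Of the compounds shown here, three that share one core have been tested in a functional assay on MIA PaCa-2 cells (Homo sapiens) for inhibition, read by MTT assay, with a stated time of 72 h, tested at 50 uM; on this read-out lower numbers stand for less inhibition of growth and higher numbers for more inhibition of growth at the one concentration tested: compound 1 (`C=CCc1ccc(OCc2cn(-c3ccccc3Cl)nn2)c(O)c1`), compound 2 (`C=CCc1ccc(OCc2cn(-c3ccc(OC)cc3)nn2)c(O)c1`) and compound 3 (`C=CCc1ccc(OCc2cn(-c3cccc(C#N)c3)nn2)c(O)c1`). Carrying 2-chlorophenyl, compound 1 gives 57.7%. Carrying 4-methoxyphenyl, compound 2 gives 88.2%. Carrying 3-cyanophenyl, compound 3 gives 41.6%, the lowest of the three numbers, and its gaps to both others lie beyond the scatter.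

The next compound, compound 4 (`C=CCc1ccc(OCc2cn(-c3ccc(Br)cc3)nn2)c(O)c1`), keeps the core and changes only the group on the aromatic nitrogen: 4-bromophenyl in place of 3-cyanophenyl on an aromatic nitrogen. All three measured steps are exchanges at this same place. The two that end on 3-cyanophenyl both go down: the modest a number 16.1 percentage points lower from compound 1 to compound 3 (beyond the scatter) and the large a number 46.6 percentage points lower from compound 2 to compound 3 (beyond the scatter). The remaining one, a number 30.5 percentage points higher from compound 1 to compound 2 (beyond the scatter), is also large, so this position has moved the number widely in this assay. Among the compounds with values here, no 4-bromophenyl compound has been measured, so the data fix the direction better than the size. Since compound 3 sits lowest, a rise is expected, larger than the modest step and smaller than the largest one. The expected change is a number 23.4 percentage points higher from compound 3 to compound 4 (beyond the scatter). Compound 4 is estimated at 65%, with an expected range of 44% to 88%.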

Compound 4, percent growth inhibition at one concentration: 47.3%
For compound 4 the middle estimate is 17.7 percentage points above the measured one; low and high end bracket the measured number.
By their numbers in this assay, from the lowest: compounds 3 and 4 (each within the scatter of the next); then compound 1; then compound 2.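

In this assay, 4-bromophenyl in place of 3-cyanophenyl gives a number 5.7 percentage points higher from compound 3 to compound 4 (within the scatter), so this exchange does not separate the two groups, and a rise at this position does not follow from leaving 3-cyanophenyl alone. The step that changes only the atom or group on the aromatic carbon of the phenyl ring, bromo in place of methoxy, is a number 40.9 percentage points lower from compound 2 to compound 4 (beyond the scatter); among the compounds shown, the high number of compound 2 therefore goes with methoxy itself and not with any group carried in the place shared by these two compounds. Against 2-chlorophenyl the change is smaller but still readable, at a number 10.4 percentage points lower from compound 1 to compound 4 (beyond the scatter), which leaves the 4-bromophenyl compound with the 3-cyanophenyl compound at the low end of the series and well short of the 4-methoxyphenyl compound.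

On these data alone, what remains open is whether the high number needs the methoxy group as such, or whether a hydroxy, an ethoxy or a dimethylamino group in the same place on the phenyl ring would hold it, and whether 3-methoxyphenyl or 2-methoxyphenyl would do the same. Nothing given here accounts for why methoxy and bromo part so widely at this position.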